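Amide variation in the pyrazolyl-propylamide series

The compounds below may be only part of what the source reports. "The series", "measured", "known", "first", "only" and "open" are said of these compounds alone.

Compound 1 `CC(=O)c1cc(C(=O)N[C@@H](C)Cn2ccc(-c3cc(F)c(C#N)c(Cl)c3)n2)n[nH]1`: 1100 nM
Compound 2 `CC(=O)c1cc(C(=O)N[C@H](C)Cn2ccc(-c3cc(F)c(C#N)c(Cl)c3)n2)n[nH]1`: 1080 nM
Compound 3 `C[C@@H](Cn1ccc(-c2ccc(C#N)c(Cl)c2)n1)NC(=O)c1ccccc1`: 1830 nM

In a functional assay on LNCaP cells (Homo sapiens) for antiproliferative activity, read by CCK-8 assay, with a stated time of 6 days (a lower number here means a stronger inhibitor, a higher number a weaker inhibitor), compound 3 shows the highest number of the three, yet its gaps to compound 1 and compound 2 lie within the scatter, so no order among them is claimed. Going by the values given here, the only measured step, a 1.0-fold lower number from compound 1 to compound 2 (0.01 log units; within the scatter), is explained by the fact that compounds 1 and 2 differ only in the configuration as drawn and says nothing about substitution on the amide ring.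

Compound 4 `CC(O)c1cccc(C(=O)N[C@@H](C)Cn2ccc(-c3ccc(C#N)c(Cl)c3)n2)c1` carries 1-hydroxyethyl in place of hydrogen on an aromatic carbon. Among the compounds with values here, no measured step bears on this change; the acetyl-bearing core of compound 1 is a different ring and not comparable one bond at a time. Without a guiding step, a move no larger than the scatter is expected, a 1.4-fold lower number from compound 3 to compound 4 (0.15 log units; within the scatter), though a polar substituent leaves the outcome open in either direction. Compound 4 is therefore estimated at 1300 nM, with a range from 450 nM to 3800 nM.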

Compound 4, half-maximal inhibitory concentration: 2280 nM
Estimate against measurement, compound 4: 1.8-fold (0.24 log units) below; low and high end bracket the measured number.
By their numbers in this assay, from the lowest: compounds 2, 1, 3 and 4 (each within the scatter of the next, the first and the last beyond it).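

In this assay, the change from phenyl to 3-(1-hydroxyethyl)phenyl gives a 1.2-fold higher number from compound 3 to compound 4 (0.10 log units; within the scatter), so this place on the amide phenyl accepts a substituent carrying a hydrogen-bond donor and acceptor without a readable shift in the number. Nothing measured for these compounds accounts for the size of this step.

Going by these compounds, whether an amine or a carboxylic acid at the same place would shift the number stays open. So does the outcome of moving 1-hydroxyethyl to another carbon of the phenyl.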